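Methoxy to methyl on the shared core of compound 2

The source may hold more compounds than are shown below. What is called first, only, known or untested is meant among the compounds shown, and "the series" means these compounds.

In a functional assay on OE21 cells (Homo sapiens) for cytotoxicity, read by MTT assay, with a stated time of 72 h (on this read-out higher numbers stand for weaker inhibition and lower numbers for stronger inhibition), compound 1 (`Cc1ccc2[nH]c(-n3cccn3)c(C3=C(Br)C(=O)NC3=O)c2c1`) gives 28000 nM and compound 2 (`COc1ccc2[nH]c3c(c4c(c5ccnn53)C(=O)NC4=O)c2c1`) gives 35000 nM. These two values lie within the scatter of each other, so compound 2 stands level with compound 1 on the numbers available. Compound 3 (`Cc1ccc2[nH]c3c(c4c(c5ccnn53)C(=O)NC4=O)c2c1`) keeps the core of compound 2, with methyl in place of methoxy on an aromatic carbon. For the measured compounds named here, no measured pair differs in one place only, so the size of this change has no direct precedent. Compound 1 also carries a methyl group, and compound 1 at 28000 nM sits within the scatter of compound 2, though its core differs. The expected result in this assay is a 1.2-fold lower number from compound 2 to compound 3 (0.07 log units; within the scatter), a step not expected to exceed the scatter in either direction. For compound 3 the estimated value is 30000 nM, with an expected range of 13000 nM to 70000 nM.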

Compound 3, half-maximal inhibitory concentration: 5000 nM
Beside the measured number, compound 3's estimate is 6.0-fold (0.78 log units) above it; measured number below the stated range.
By their numbers in this assay, from the lowest: compound 3; then compounds 1 and 2 (each within the scatter of the next).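

In this assay, methyl in place of methoxy on an aromatic carbon gives a 7.0-fold lower number from compound 2 to compound 3 (0.85 log units; beyond the scatter). For the compounds shown here, this is the first single-place step, and it shows that the number responds to the group at this position on the shared core. Compounds 1 and 2 could not show this, since they differ in more than one place and their values lie within the scatter of each other.

A single pair cannot show whether the step belongs to methyl itself or to the loss of methoxy, and an amine, a chlorine or a longer chain such as ethyl at this carbon would help separate the two. Whether the same change would carry over to another core stays open, and no measurement at hand accounts for the step.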